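The compounds below may be only part of what the source reports. "The series", "measured", "known", "first", "only" and "open" are said of these compounds alone.

Compound 1 `COc1cc(CN(CC(C)C)C(CC(=O)O)c2ccc3c(c2)CCO3)ccc1OCCN1C(=O)CCC1=O` gives 41 nM in an assay on CHO cells for displacement of a labelled ligand from C-X-C chemokine receptor type 3 (Homo sapiens), with a stated time of 60 min; on this read-out higher numbers stand for weaker inhibition and lower numbers for stronger inhibition. Compound 2 `COc1cc(CN(CC(C)C)C(CC(=O)O)c2ccc(Cl)cc2)ccc1OCCN1C(=O)CCC1=O` gives 34 nM in this assay. Compound 3 `COc1cc(CN(CC(C)C)C(CC(=O)O)c2ccc(Cl)cc2Cl)ccc1OCCN1C(=O)CCC1=O` gives 110 nM in this assay.

Compound 3 stands highest of the three numbers: a 2.7-fold higher number from compound 1 to compound 3 (0.43 log units; beyond the scatter) and a 3.2-fold higher number from compound 2 to compound 3 (0.51 log units; beyond the scatter). Compound 4 `COc1cc(CN(CC(C)C)C(CC(=O)O)c2ccc(Cl)c(F)c2)ccc1OCCN1C(=O)CCC1=O` differs from compound 3 by 4-chloro-3-fluorophenyl in place of 2,4-dichlorophenyl on a saturated chain carbon bound to an amine nitrogen and a saturated chain carbon. The step of a 3.2-fold higher number from compound 2 to compound 3 (0.51 log units; beyond the scatter) bears most directly on this change: compound 4 gives up the chloro that compound 3 carries and compound 2 lacks. The step of a 1.2-fold lower number from compound 1 to compound 2 (0.08 log units; within the scatter) shows that the aryl group on that carbon can be exchanged without a step beyond the scatter. Going by the values given here, no measured step covers a fluorine on this ring, so that part stays open. Compound 4 is therefore expected to come down, by an estimated 2.4-fold lower number from compound 3 to compound 4 (0.39 log units; beyond the scatter). Compound 4 is estimated at 45 nM, with a range of 20 nM to 110 nM.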

Compound 4, half-maximal inhibitory concentration: 70 nM
For compound 4 the middle estimate is 1.6-fold (0.19 log units) below the measured one, and the stated range covers the measured number.
By their numbers in this assay, from the lowest: compounds 2, 1, 4 and 3 (each within the scatter of the next, the first and the last beyond it).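

A fluoro added to this aryl ring gives a step beyond the scatter (a 2.1-fold higher number from compound 2 to compound 4 (0.31 log units; beyond the scatter)), so chloro is not the only added halogen on this ring to raise the number. Yet 4-chloro-3-fluorophenyl in place of 2,4-dichlorophenyl stays within the scatter (a 1.6-fold lower number from compound 3 to compound 4 (0.20 log units; within the scatter)), as does its exchange for the bicyclic group of the first compound (a 1.7-fold higher number from compound 1 to compound 4 (0.23 log units; within the scatter)). No measurement shown explains these steps. The compounds shown leave open how a methoxy, a nitrile or an amine on this aryl ring would compare.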